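The source may report more compounds than this note shows. Statements on the series, on what has been measured and on what is new or still open speak of the compounds shown alone.

For the measured compounds named here, compound 1 `Cn1c(=O)c(S(=O)(=O)c2ccc(F)cc2F)cc2cnc(Nc3cccc4[nH]ccc34)nc21` is the stronger of the two compounds measured so far in a functional assay on DU-145 cells (Homo sapiens) for inhibition, read by trypan blue exclusion, with a stated time of 72 h; a higher number here means a weaker inhibitor, a lower number a stronger inhibitor: compound 1 gives 750 nM, while compound 2 `Cc1ccc(S(=O)(=O)c2cc3cnc(Nc4ccc5cc[nH]c5c4)nc3n(C)c2=O)cc1` gives 15000 nM, a gap that lies beyond the scatter of repeated measurements. The two compounds differ in more than one place, so the numbers show only the overall gap and not what any single change does.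

Compound 3 `Cn1c(=O)c(S(=O)(=O)c2ccc(F)cc2F)cc2cnc(Nc3ccccn3)nc21` has not yet been measured. It differs from compound 1 in one place: pyridin-2-yl in place of 1H-indol-4-yl on a nitrogen on an aromatic ring. Going by the values given here, no single-change step between measured compounds is known, so there is no direct guide to how much this swap matters. The group that leaves is larger and carries a hydrogen-bond donor; the one that enters is smaller and carries an acceptor instead. The expectation is a loss of potency, with a step of a 4.7-fold higher number from compound 1 to compound 3 (0.67 log units; beyond the scatter) that goes beyond the scatter. Compound 3 is therefore estimated at 3500 nM, with a likely range from 900 nM to 14000 nM.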

Compound 3, half-maximal inhibitory concentration: 75000 nM
The estimate for compound 3 lay 21-fold (1.33 log units) below the measured number, outside the stated range (above it).
By their numbers in this assay, from the lowest: compound 1; then compound 2; then compound 3.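

In this assay, putting pyridin-2-yl in place of 1H-indol-4-yl on a nitrogen on an aromatic ring gives a 100-fold higher number from compound 1 to compound 3 (2.00 log units; beyond the scatter). The rest of the structure stays the same, so this large loss belongs to this one place, something the earlier pair, which differed in more than one place, could not show. Nothing available here explains why this swap costs so much potency.

The swap replaces two rings with one and exchanges a hydrogen-bond donor for an acceptor, so the compounds shown cannot separate these differences. Going by these compounds, a plain phenyl group would keep a single ring without the ring nitrogen, and a 3-aminophenyl group would add an amine to that ring, so how either would fare at this place remains open.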